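The source may hold more compounds than are shown below. What is called first, only, known or untested is meant among the compounds shown, and "the series" means these compounds.

Measured so far:
Compound 1, `CCOC(=O)/C=C\NC(=O)[C@H](O)C(C)(C)CO`: 1%
Compound 2, `CC(C)(C)OC(=O)/C=C\NC(=O)[C@@H](O)C(C)(C)CO`: 26%

In an ADME assay on WI-38 cells (Homo sapiens) for inhibition, read by CellTiter-Glo, with a stated time of 48 h, tested at 100 uM (a lower number here means less inhibition, a higher number more inhibition at the concentration tested (going by the name of the read-out)), compound 2 gives the higher of the two numbers shown, and compound 1 gives a value that lies a good way below it, a gap beyond the scatter. Compound 3, `CCOC(=O)/C=C\NC(=O)[C@@H](O)C(C)(C)CO`, has not yet been measured. It differs from compound 2 by ethyl in place of tert-butyl on an oxygen next to a carbonyl group. Among the compounds with values here, with no step between measured compounds to lean on, the account expects the step of a number 18 percentage points lower from compound 2 to compound 3 (beyond the scatter) to run downward, since compound 1, which also carries the ethyl, gives 1%. Compound 3 is therefore estimated at 8%, within 0% to 22%.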

Compound 3, a percentage reported as inhibition, at one concentration (the size of the read-out at that concentration, not a potency): -6%
Beside the measured number, compound 3's estimate is 14 percentage points above it; the whole stated range lies above it.
By their numbers in this assay, from the lowest: compounds 3 and 1 (each within the scatter of the next); then compound 2.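

In this assay, ethyl in place of tert-butyl on an oxygen next to a carbonyl group can now be read as a single change, and it gives a number 32 percentage points lower from compound 2 to compound 3 (beyond the scatter). Within the ethyl pair, changing the drawn stereocentre gives a number 7 percentage points lower from compound 1 to compound 3 (within the scatter), so configuration at that carbon shows no readable effect in this pair. That reading rests on a clean comparison: the fact that compounds 1 and 3 differ only in the configuration as drawn

The compounds shown leave open how a longer chain or a benzyl group on that oxygen would read. They also leave open whether configuration is equally silent with tert-butyl in place.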